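Stereochemical rearrangement of a cyclobutane bis-aroyl scaffold

This account rests on a few compounds, and the source may have more. Where it says the series, first, only, none or still open, it means among the compounds named here.

In a functional assay on PC-3 cells (Homo sapiens) for cytotoxicity, read by MTT assay, with a stated time of 48 h, tested at 25 uM (a higher number here means a stronger effect of the compound at the concentration tested, a lower number a weaker effect), three diastereomeric compounds have been examined so far. Compound 1, `O=C(c1ccc(O)cc1O)[C@H]1[C@H](c2ccccc2)[C@H](C(=O)c2ccc(O)cc2O)[C@H]1c1ccccc1`, gives 88%. Compound 3, `O=C(c1ccc(O)cc1O)[C@H]1Cc2ccccc2[C@@H](C(=O)c2ccc(O)cc2O)[C@H]1c1ccccc1`, gives 86.3%. Compound 2, `O=C(c1ccc(O)cc1O)[C@@H]1[C@@H](C(=O)c2ccc(O)cc2O)[C@H](c2ccccc2)[C@@H]1c1ccccc1`, gives 75.5%, which is the lowest of the three numbers; its gap to compound 3 and its gap to compound 1 both lie beyond the usual scatter, so compound 2 is the weakest of the measured set in this assay.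

Compound 4, `O=C(c1ccc(O)cc1O)[C@H]1[C@H](C(=O)c2ccc(O)cc2O)[C@@H](c2ccccc2)[C@@H]1c1ccccc1`, has not yet been measured. It differs from compound 2 as follows: the two compounds have the same atoms and bonds and differ only in configuration as drawn: 3 of 4 stereo elements differ; a stereocentre at a saturated ring carbon is drawn S in compound 2 and R in compound 4; a stereocentre at a saturated ring carbon is drawn S in compound 2 and R in compound 4; a stereocentre at a saturated ring carbon is drawn R in compound 2 and S in compound 4

Among the compounds with values here, no step between two measured compounds that differ in a single place has been recorded, so the effect of such a change in configuration cannot be read directly. The three measured values all fall in the upper range, so compound 4 is expected to land in that range as well. The step from compound 2 to compound 4 is estimated at a number 6.5 percentage points higher from compound 2 to compound 4 (within the scatter), an upward shift not clearly beyond the scatter. Compound 4 is therefore expected to give about 82%, with a range from 68% to 92%.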

Compound 4, a percentage reported as activity, at one concentration (the size of the read-out at that concentration, not a potency): 97.6%
For compound 4 the middle estimate is 15.6 percentage points below the measured one; the measured number lies above the stated range.
By their numbers in this assay, from the lowest: compound 2; then compounds 3, 1 and 4 (each within the scatter of the next, the first and the last beyond it).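

In this assay the series now holds its first readable step, a number 22.1 percentage points higher from compound 2 to compound 4 (beyond the scatter), and it shows that configuration at the saturated ring carbons can by itself move the read-out beyond the scatter. No group enters or leaves, so this step can be attributed to configuration alone: the fact that compounds 2 and 4 differ only in the configuration as drawn. Three of the four stereo elements change together, however, so the step belongs to that combined change and not to any single stereocentre.

Which of the three stereocentres carries the step remains open, as does whether a change at just one of them would be enough. Also open, going by these compounds, is whether the same difference between compound 2 and compound 4 would persist with a methoxy group or an amine in place of the hydroxyl groups on the shared core.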